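Amide Variation on a Fluorinated Naphthalene Phosphatase Inhibitor Series

The source may report more compounds than this note shows. Statements on the series, on what has been measured and on what is new or still open speak of the compounds shown alone.

Compound 1 `CCN(CC)C(=O)COc1ccc2cc(C(O)(C(F)(F)F)C(F)(F)F)c(O)cc2c1` gives > 20000 nM in an assay on isolated protein for inhibition of receptor-type tyrosine-protein phosphatase C (Homo sapiens), read by spectrophotometry (on this read-out lower numbers stand for stronger inhibition and higher numbers for weaker inhibition), which is a limit of the measurement rather than a number.
Compound 2 `O=C(COc1ccc2cc(C(O)(C(F)(F)F)C(F)(F)F)c(O)cc2c1)Nc1ccccc1` gives > 20000 nM in this assay, again only a limit.
Compound 3 `CCCNC(=O)COc1ccc2cc(C(O)(C(F)(F)F)C(F)(F)F)c(O)cc2c1` gives > 20000 nM in this assay, also a limit.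

All three measured values sit at the same limit (the limit of > 20000 nM in this assay, at which 3 of the 3 values shown sit), so compound 3 stands nowhere that can be ranked against the other two: none of the three is distinguished from the others. The steps among them, a step that the two limits leave unreadable from compound 1 to compound 2, a step that the two limits leave unreadable from compound 1 to compound 3 and a step that the two limits leave unreadable from compound 2 to compound 3, are accordingly unreadable in size and direction. Compound 4 `COc1ccc(CNC(=O)COc2ccc3cc(C(O)(C(F)(F)F)C(F)(F)F)c(O)cc3c2)cc1OC` differs from compound 3 by 3,4-dimethoxyphenyl in place of ethyl on a saturated chain carbon bound to an amide-type nitrogen. Going by the values given here, no measured step bears on this change in a readable way; the only guide is that exchanging the amide substituent among diethylamino, anilino and propylamino produced nothing that rose above the limit. Compound 4 is therefore expected to remain at or near that limit, and the step that the limit leaves unreadable from compound 3 to compound 4 is expected to be too small to be readable. The estimate for compound 4 in this assay is 25000 nM, within a range from 5000 nM to 100000 nM, with a substantial chance that only a limit is reported.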

Compound 4, half-maximal inhibitory concentration: > 20000 nM
Compound 4 gave a limit, no number; the forecaster's own chance of this, stated with the estimate: 70%; the middle value does not contradict the limit.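

Compound 4, like compound 1, compound 2 and compound 3, gives only a limit, so none of the steps from those three compounds to compound 4 can be read: the limit of > 20000 nM in this assay, at which 4 of the 4 values shown sit.

The compounds shown leave open whether any amide substituent on the shared core gives a measurable inhibition in this assay, and how far these four compounds actually differ.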